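The compounds below may be only part of what the source reports. "The series", "measured", "known", "first", "only" and "open" are said of these compounds alone.

Among the compounds with values here, in a functional assay on cells (Homo sapiens), read by thymidine incorporation (on this read-out lower numbers stand for stronger inhibition and higher numbers for weaker inhibition), the series so far holds two compounds on a shared core. Compound 1 `Clc1ccccc1-c1cc(NCc2cccnc2)n2ncc(Br)c2n1` gives 500 nM; 500 nM (2 entries) in both of its entries. Compound 2 `Brc1cnn2c(NCc3cccnc3)cc(C3CCCCC3)nc12` gives 200 nM, a single number and the lower of the two values. Compound 3 `Brc1cnn2c(NCc3cccnc3)cc(-c3ccco3)nc12`, not yet measured, differs from compound 2 at one place: furan-2-yl in place of cyclohexyl on an aromatic carbon. Within the data shown here, no measured pair isolates this change. Among the measured compounds shown here, the only compound so far with an aromatic ring at this place is compound 1, at 500 nM; 500 nM (2 entries), so a small move toward weaker inhibition is expected, of a size close to the usual scatter. The expected change is a 1.5-fold higher number from compound 2 to compound 3 (0.18 log units; within the scatter). For compound 3 the estimated value in this assay is 300 nM, with an expected range of 100 nM to 900 nM.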

Compound 3, half-maximal inhibitory concentration: 15200 nM
Beside the measured number, compound 3's estimate is 51-fold (1.70 log units) below it; the measured number lies above the stated range.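

In this assay, the aromatic carbon bearing this group proves highly sensitive to the substituent: furan-2-yl in place of cyclohexyl gives a 76-fold higher number from compound 2 to compound 3 (1.88 log units; beyond the scatter). An aromatic ring at this place does not by itself set the level of inhibition, as compound 1, also aromatic here, gives 500 nM; 500 nM (2 entries), whereas compound 3 gives 15200 nM. Nothing available bears on the origin of this large step, so it remains unassigned.

Still open, going by these compounds, is whether the weaker inhibition of compound 3 goes with the ring oxygen, the five-membered ring or the aromatic ring itself. Cyclopentyl, tetrahydrofuran-2-yl and thiophen-2-yl groups at this place would separate these three features, while a piperidin-1-yl group would show how a ring amine is tolerated there.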